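The source may report more compounds than this note shows. Statements on the series, on what has been measured and on what is new or still open speak of the compounds shown alone.

Measured in a functional assay on BV-2 cells (Mus musculus) for inhibition, read by Griess assay, with a stated time of 24 h; on this read-out lower numbers stand for stronger inhibition and higher numbers for weaker inhibition:

Compound 1 `C/C(C=O)=C1\CC[C@](C)(O)[C@]23C[C@H](/C=C(C)/C=C/[C@@H]4[C@@H](C(C)(C)O)CC[C@@]4(C)O)O[C@H]2OCCC[C@H]13`: > 10000 nM
Compound 2 `CC(/C=C/[C@H]1[C@H](C(C)(C)O)CC[C@]1(C)O)=C\[C@H]1C[C@@]23[C@H](OCCC[C@@H]2/C(=C(\C)C=O)CC[C@]3(C)O)O1`: > 10000 nM
Compound 3 `C=C(C)[C@H]1CC[C@@](C)(O)[C@@H]1/C=C/C(C)=C/[C@H]1C[C@@]23[C@H](OCCC[C@@H]2/C(=C(\C)C=O)CC[C@]3(C)O)O1`: > 10000 nM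

Compound 3 gives > 10000 nM, which is a limit of this assay and not a number. Among the compounds with values here, compounds 1 and 2 share that limit, so the whole series so far comes down to the limit of > 10000 nM in this assay, at which 3 of the 3 values shown sit, and no ranking can be read from it.

Compound 4 `C=C(C)[C@H]1CC[C@@](C)(O)[C@@H]1/C=C/C(C)=C/[C@H]1C[C@@]23[C@H](OCCC[C@@H]2/C(=C(/C)C=O)CC[C@]3(C)O)O1` is the next to be considered: the two compounds have the same atoms and bonds and differ only in configuration as drawn: 1 of 11 stereo elements differ; a double bond is drawn E in compound 3 and Z in compound 4. The two compounds have the same atoms and bonds, and a double bond is drawn E in compound 3 and Z in compound 4.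

Within the data shown here, two measured steps bear on this. The closer in kind is a step that the two limits leave unreadable from compound 1 to compound 2, which rests on (the fact that compounds 1 and 2 differ only in the configuration as drawn). That step includes a change of double-bond configuration, though along with other changes. The other is a step that the two limits leave unreadable from compound 2 to compound 3, the change that produced the 2-hydroxy-2-methyl-5-(1-methylethenyl)cyclopentyl group that compound 4 keeps. Neither step has a readable size, and neither shows any compound leaving the limit. No shift beyond the scatter, in either direction, is therefore expected in this assay. The expected step is a step that the limit leaves unreadable from compound 3 to compound 4. Compound 4 is estimated at 12000 nM, with an expected range of 5000 nM to 30000 nM, and it will most likely be reported as a limit once more.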

Compound 4, half-maximal inhibitory concentration: > 10000 nM
Compound 4 was reported as a limit (the forecaster's own chance of this, stated with the estimate: 85%); the middle value lies beyond the limit too.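

In this assay compound 4 gives > 10000 nM, which is a limit of the assay and not a number. No new step can be read for compound 4, neither against compound 3 nor against compound 1, as those compounds sit at the same limit. The compounds shown leave open whether any of these structural changes alters inhibition at all.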